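The source may report more compounds than this note shows. Statements on the series, on what has been measured and on what is new or still open speak of the compounds shown alone.

Compound 1 `N#Cc1c(-c2ccccc2)cn(-c2ccc(S(=O)(=O)Nc3ccccn3)cc2)c1N` gives 4600 nM in a functional assay on MCF7 cells (Homo sapiens) for inhibition, read by sulforhodamine B assay, with a stated time of 24 h; on this read-out higher numbers stand for weaker inhibition and lower numbers for stronger inhibition. Among the three measured compounds its number is the smallest, but compound 3 `O=c1[nH]cnc2c1c(-c1ccccc1)cn2-c1ccc(S(=O)(=O)Nc2ccccn2)cc1` gives 5320 nM and compound 2 `O=c1[nH]cnc2c1c(-c1ccccc1)cn2-c1ccc(S(=O)(=O)Nc2nccs2)cc1` gives 6210 nM, and both gaps lie within the scatter, so the three stand together. Among the measured compounds shown here, the only single-place step among them, a 1.2-fold lower number from compound 2 to compound 3 (0.07 log units; within the scatter), concerns the sulfonamide nitrogen and not the site altered here. Compound 4 `N#Cc1c(-c2ccccc2)cn(-c2ccc(S(=O)(=O)Nc3ccccn3)cc2)c1NC(=O)CCC(=O)O` differs from compound 1 by (2-carboxyethyl)carbonyl in place of hydrogen on a nitrogen on an aromatic ring. For the measured compounds named here, no measured step bears on this change, so compound 1 alone anchors the expectation, and no movement beyond the scatter is expected. For compound 4 the estimated value in this assay is 6000 nM, between 2500 nM and 15000 nM. This estimate means a step of a 1.3-fold higher number from compound 1 to compound 4 (0.12 log units; within the scatter), expected to stay within the scatter.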

Compound 4, half-maximal inhibitory concentration: 8320 nM
The estimate for compound 4 lay 1.4-fold (0.14 log units) below the measured number, within the range that was stated.
By their numbers in this assay, from the lowest: compounds 1, 3, 2 and 4 (each within the scatter of the next).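

In this assay, among the compounds shown here, the change from amino to ((2-carboxyethyl)carbonyl)amino gives the first reading at this nitrogen on an aromatic ring, and a 1.8-fold higher number from compound 1 to compound 4 (0.26 log units; within the scatter) shows that this large addition, carrying a free carboxylic acid, leaves the number within the scatter. The earlier compounds shown here spoke only to the sulfonamide nitrogen. No evidence here explains why the number holds at this position.

The compounds shown leave open whether an acetyl group, a longer chain, a methyl ester or a terminal amine at this nitrogen would behave alike. They also leave open whether any such group could move the number beyond the scatter.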